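Working notes: amide nitrogen substituent, compound 2 to compound 3

The compounds below may be only part of what the source reports. "The series", "measured", "known", "first", "only" and "open" are said of these compounds alone.

- compound 1 `CN1C[C@H](C(=O)Nc2cccc(F)c2)[C@@H](c2ccc(/C=C/C(=O)Nc3ccccc3N)cc2)C1`: 56 mL/min/kg
- compound 2 `CN1C[C@H](C(=O)Nc2cccnc2)[C@@H](c2ccc(/C=C/C(=O)Nc3ccccc3N)cc2)C1`: 41 mL/min/kg

In an in vitro ADME assay on microsomes from liver (Mus musculus) for pharmacokinetics, read by LC-MS, with a stated time of 10 min, tested at 1 uM (on this read-out lower numbers stand for slow clearance and higher numbers for fast clearance), compound 2 gives 41 mL/min/kg, which lies within the scatter of compound 1 at 56 mL/min/kg. Compound 3 `CN1C[C@H](C(=O)NC2CC2)[C@@H](c2ccc(/C=C/C(=O)Nc3ccccc3N)cc2)C1` has cyclopropyl in place of pyridin-3-yl on an amide-type nitrogen. For the measured compounds named here, the only measured step at this place, a 1.4-fold lower number from compound 1 to compound 2 (0.14 log units; within the scatter), stays within the scatter. Going by the values given here, no measured compound carries a non-aromatic ring there, so the direction remains open and the range is wide. No step beyond the scatter is expected, and the estimated step is a 1.0-fold lower number from compound 2 to compound 3 (0.01 log units; within the scatter). For compound 3 the expected value is 40 mL/min/kg, with an estimated range of 20 mL/min/kg to 80 mL/min/kg.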

Compound 3, clearance: 7 mL/min/kg
Compound 3: the middle estimate sits 5.7-fold (0.76 log units) above what was measured; measured number below the stated range.
By their numbers in this assay, from the lowest: compound 3; then compounds 2 and 1 (each within the scatter of the next).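

In this assay, the substituent on the amide-type nitrogen can move the number beyond the scatter: a 5.9-fold lower number from compound 2 to compound 3 (0.77 log units; beyond the scatter) with cyclopropyl in place of pyridin-3-yl, and an 8.0-fold lower number from compound 1 to compound 3 (0.90 log units; beyond the scatter) with cyclopropyl in place of 3-fluorophenyl. Among these compounds, only the steps to the three-membered non-aromatic ring leave the scatter, while the step between the two aromatic groups does not. Nothing at hand bears on the reason for these steps. As far as these compounds go, whether cyclohexyl or an open chain such as ethyl on the same nitrogen would also give a low number remains open.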